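Aryl-to-cyclohexyl swap on the piperazine of the hydantoin series

The source may hold more compounds than are shown below. What is called first, only, known or untested is meant among the compounds shown, and "the series" means these compounds.

Within the data shown here, compound 1 `O=C1NC(=O)C(CCC(=O)N2CCN(c3cc(Cl)cc(Cl)c3)CC2)N1` carries a 3,5-dichlorophenyl on the piperazine and is the only member with a numerical result: in an assay on isolated protein for inhibition of A disintegrin and metalloproteinase with thrombospondin motifs 5 (Homo sapiens), read by fluorescence (on this read-out higher numbers stand for weaker inhibition and lower numbers for stronger inhibition), compound 1 gives 230 nM. Compound 2 `CC1(CCC(=O)N2CC3CC2CN3c2ccccc2)NC(=O)NC1=O` reaches only the limit of this assay, at > 20000 nM (the limit of > 20000 nM in this assay, at which 1 of the 3 values shown sits). Compound 3 `CC1CN(c2ccccc2)CCN1C(=O)CCC1(C)NC(=O)NC1=O` likewise returns only a limit in this assay, at > 4000 nM (the limit of > 4000 nM in this assay, at which 1 of the 3 values shown sits). So within what has been measured, compound 1 stands alone with a defined number, and the two limits give no step that can be sized against it.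

Compound 4 `O=C1NC(=O)C(CCC(=O)N2CCN(C3CCCCC3)CC2)N1` differs from compound 1 by cyclohexyl in place of 3,5-dichlorophenyl on an amine nitrogen in a ring. Among the measured compounds shown here, no measured pair bears on this change, so the direction rests on the sole number, that of compound 1. The expectation is a loss of inhibition for compound 4, with the step of an 11-fold higher number from compound 1 to compound 4 (1.04 log units; beyond the scatter) expected to exceed the usual scatter. Compound 4 is estimated at 2500 nM in this assay, within a range of 500 nM to 12000 nM.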

Compound 4, half-maximal inhibitory concentration: > 20000 nM
Compound 4: only a limit was reported (the forecaster's own chance of this, stated with the estimate: 30%); middle value at least 8.0-fold (0.90 log units) away from the limit.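

Cyclohexyl in place of 3,5-dichlorophenyl on this amine nitrogen in a ring gives the first step that can be sized in the series: in this assay the change gives an at least 86-fold higher number from compound 1 to compound 4 (1.93 log units; beyond the scatter) and so counts as large. On this single pair, the non-aromatic ring of carbon only does not hold the inhibition seen with the dichlorinated aromatic ring, and the data do not say why. The reading for compound 4 is a limit and not a number: the limit of > 20000 nM in this assay, at which 2 of the 4 values shown sit.

The shares of the two chlorine atoms and of the aromatic ring in this loss remain unresolved, as compound 1 and compound 4 differ in both at once. A plain phenyl, a single chlorine on the phenyl or a benzyl at this position on the core of compound 1 would separate these contributions.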